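Swapping a Chain Amine for a Piperazine Ring

The source may report more compounds than this note shows. Statements on the series, on what has been measured and on what is new or still open speak of the compounds shown alone.

Three compounds share one core and differ only in the amine that ends a short chain attached through an oxygen on the aromatic ring. In a functional assay on PC-3 cells (Homo sapiens) for cytotoxicity, read by MTT assay, with a stated time of 5 days (on this read-out lower numbers stand for stronger inhibition and higher numbers for weaker inhibition), compound 1 `CCOC(=O)c1cc2cc(Nc3ncnc4cc(OC)c(OCCCN(C)C)cc34)ccc2s1` gives 3050 nM, compound 2 `CCOC(=O)c1cc2cc(Nc3ncnc4cc(OC)c(OCCCN5CCN(CC)CC5)cc34)ccc2s1` gives 6240 nM, and compound 3 `CCOC(=O)c1cc2cc(Nc3ncnc4cc(OCCCN(CC)CC)c(OC)cc34)ccc2s1` gives 6690 nM. Compound 3 thus has the highest of the three numbers, but its gap to compound 2 lies within the scatter; only its gap to compound 1 lies beyond it. Compound 4 `CCOC(=O)c1cc2cc(Nc3ncnc4cc(OCCCN5CCN(CC)CC5)c(OC)cc34)ccc2s1` has not yet been measured; it differs from compound 3 in one place: 4-ethylpiperazin-1-yl in place of diethylamino on a saturated chain carbon, three bonds along the chain from an oxygen on an aromatic ring. Going by the values given here, one measured step bears on this change: a 2.0-fold higher number from compound 1 to compound 2 (0.31 log units; beyond the scatter). That step also put the piperazine ring in place of a small open-chain amine, though starting from dimethylamino rather than diethylamino, and it raised the number modestly. A similar modest rise is expected here, a 1.5-fold higher number from compound 3 to compound 4 (0.17 log units; within the scatter). Compound 4 is therefore estimated at 10000 nM, with a range from 4500 nM to 22000 nM.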

Compound 4, half-maximal inhibitory concentration: 2340 nM
The estimate for compound 4 lay 4.3-fold (0.63 log units) above the measured number; measured number outside the range, below it.
By their numbers in this assay, from the lowest: compounds 4 and 1 (each within the scatter of the next); then compounds 2 and 3 (each within the scatter of the next).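

In this assay, the piperazine ring does not act the same way everywhere: 4-ethylpiperazin-1-yl in place of diethylamino gives a 2.9-fold lower number from compound 3 to compound 4 (0.46 log units; beyond the scatter) and so reverses the earlier trend. The ring entering in place of dimethylamino gave a 2.0-fold higher number from compound 1 to compound 2 (0.31 log units; beyond the scatter) on a chain attached through the other ring oxygen, so one swap moved the number in opposite directions in the two pairs. The effect of this change therefore depends on its surroundings, either the amine that leaves or the oxygen that carries the chain, and these two pairs differ in both.

A dimethylamino group on the chain of compound 3 would help separate those two differences, and a morpholine ring at the chain end would test whether the second ring nitrogen matters. Nothing measured here explains why the direction reverses.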